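The source may report more compounds than this note shows. Statements on the series, on what has been measured and on what is new or still open speak of the compounds shown alone.

Measured compounds:
- compound 1 `CC1(C)Cc2c(sc(NC(=O)C3CNC(=O)C3)c2C(N)=O)C(C)(C)O1` — > 10000 nM
- compound 2 `CC1(C)Cc2c(sc(NC(=O)c3[nH]ncc3Cl)c2C(N)=O)C(C)(C)O1` — 2 nM
- compound 3 `CC1(C)Cc2c(sc(NC(=O)c3cc(C(F)(F)F)n[nH]3)c2C(N)=O)C(C)(C)O1` — 3 nM

In an assay on cells for positive allosteric modulation of Cystic fibrosis transmembrane conductance regulator variant F508del (Homo sapiens), with stated times of 10 min and 7 s, in the presence of a further agent that is not named here (a lower number here means that less compound is needed, a higher number that more compound is needed for the effect), compound 1 gives > 10000 nM, which is a limit of the assay rather than a number; it sits at the limit of > 10000 nM in this assay, at which 1 of the 3 values shown sits. In this assay compound 2 gives 2 nM. In this assay compound 3 gives 3 nM, the higher of the two numbers shown, with compound 2 nearest to it; the step of a 1.5-fold higher number from compound 2 to compound 3 (0.18 log units; within the scatter) is within the scatter, so the two cannot be ordered.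

The steps from the shared core carrying the lactam to the two pyrazole amides were large: an at least 5000-fold lower number from compound 1 to compound 2 (3.69 log units; beyond the scatter) and an at least 3300-fold lower number from compound 1 to compound 3 (3.52 log units; beyond the scatter).

Compound 4 `Cc1n[nH]c(C(=O)Nc2sc3c(c2C(N)=O)CC(C)(C)OC3(C)C)c1Cl` has not been measured. The change from compound 3 is a group of 7 heavy atoms (4 carbon, 2 nitrogen, 1 chlorine; one five-membered aromatic ring with 2 hetero atoms) in place of a group of 9 heavy atoms (4 carbon, 2 nitrogen, 3 fluorine; one five-membered aromatic ring with 2 hetero atoms), on a carbonyl carbon. The ring entering resembles that of compound 2, with a methyl added, and the step of a 1.5-fold higher number from compound 2 to compound 3 (0.18 log units; within the scatter) between the two pyrazole amides already measured was within the scatter; on that basis compound 4 is expected to stay close to compound 3 in this assay, with no change at the digits printed from compound 3 to compound 4 (within the scatter) not beyond the scatter. The estimate for compound 4 is 3 nM, between 1 nM and 10 nM.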

Compound 4, half-maximal effective concentration: 11 nM
For compound 4 the middle estimate is 3.7-fold (0.56 log units) below the measured one; measured number above the stated range.
By their numbers in this assay, from the lowest: compounds 2 and 3 (each within the scatter of the next); then compound 4. At a limit, above all of these: compound 1.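

Pyrazole amides on the shared core could not be ordered until now, but in this assay methyl in place of hydrogen on an aromatic carbon is a step beyond the scatter, a 5.5-fold higher number from compound 2 to compound 4 (0.74 log units; beyond the scatter), and the ring of compound 4 also separates from 3-(trifluoromethyl)-1H-pyrazol-5-yl, a 3.7-fold higher number from compound 3 to compound 4 (0.56 log units; beyond the scatter). These modest steps remain small beside an at least 900-fold lower number from compound 1 to compound 4 (2.95 log units; beyond the scatter), a step that rests on a limit of the assay for compound 1. Nothing measured here gives a cause for the methyl step.

As far as these compounds go, whether an ethyl or an amino group in place of the methyl would give a larger step remains open. So does whether the methyl step would hold with hydrogen or bromine in place of the chlorine.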